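Trimming a Long Arm Down to an Ethoxy Group

The compounds below may be only part of what the source reports. "The series", "measured", "known", "first", "only" and "open" are said of these compounds alone.

In a functional assay on Ehrlich cells (Mus musculus) for cytotoxicity, read by trypan blue exclusion, with a stated time of 2 h (a higher number here means a weaker inhibitor, a lower number a stronger inhibitor), compound 1 `N#CC1=C(NC(=O)c2ccc([N+](=O)[O-])cc2)N(c2ccc(S(N)(=O)=O)cc2)C2=C(C(=O)CCC2)C1c1ccc(Cl)cc1Cl` gives 50 ug/mL. Compound 2 `CN(C)c1ccc(/C=C/C=N/C2=C(C#N)C(c3ccc(Cl)cc3Cl)C3=C(CCCC3=O)N2c2ccc(S(N)(=O)=O)cc2)cc1` gives only > 100 ug/mL, which is a limit of this assay rather than a number, so compound 2 sits at the limit of > 100 ug/mL in this assay, at which 1 of the 2 values shown sits. Compound 3 `CCO/C=N/C1=C(C#N)C(c2ccc(Cl)cc2Cl)C2=C(CCCC2=O)N1c1ccc(S(N)(=O)=O)cc1` differs from compound 2 by ethoxy in place of 2-(4-(dimethylamino)phenyl)ethenyl on a carbon with a double bond to nitrogen. Among the measured compounds shown here, with no measured step of this kind to lean on, the change from compound 2 to compound 3 is expected to amount to a number no higher from compound 2 to compound 3 (the limit leaves the size open), a step no larger than the usual scatter. Compound 3 is therefore expected to give 100 ug/mL, within 40 ug/mL to 250 ug/mL.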

Compound 3, half-maximal inhibitory concentration: > 100 ug/mL
Compound 3: only a limit was reported; the forecaster's own chance of this, stated with the estimate: 45%; the middle value sits exactly at the limit.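

Replacing the long 2-(4-(dimethylamino)phenyl)ethenyl arm with ethoxy, on a carbon with a double bond to nitrogen, still gives no true number in this assay, so the step between these two compounds cannot be read: the limit of > 100 ug/mL in this assay, at which 2 of the 3 values shown sit. Among the compounds shown here, the one readable step is an at least 2.0-fold higher number from compound 1 to compound 3 (0.30 log units; that floor lies within the scatter), which does not establish a real difference. From the compounds shown here alone, whether an amine or a longer alkoxy chain on this carbon would give a true number remains open. Going by these compounds, how far the real values of compound 2 and compound 3 lie past the limit also remains unknown.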